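A few compounds are considered here, and "the series" means these few. Any claim that something is new, unique, unknown or untested is made for them only; others in the source may bear on it.

Measured compounds:
compound 1, `COc1cc(-c2nn(-c3cccc(NC(=O)Nc4cc(C(F)(F)F)cc(C(F)(F)F)c4)c3)cc2-c2ccncc2)ccc1Cl` — 847 nM
compound 2, `COc1cc(-c2nn(-c3cccc(NC(=O)c4cccc(C(F)(F)F)c4)c3)cc2-c2ccncc2)ccc1Cl` — 1640 nM
compound 3, `O=C(Nc1cccc(-n2cc(-c3ccncc3)c(-c3ccc(Cl)c(O)c3)n2)c1)Nc1ccc(Cl)c(Cl)c1` — 3960 nM

In a functional assay on COLO 205 cells (Homo sapiens) for inhibition, read by sulforhodamine B assay, with a stated time of 48 h (a higher number here means a weaker inhibitor of growth, a lower number a stronger inhibitor of growth), compound 2 gives 1640 nM, the second highest of the three numbers. Compound 1 gives 847 nM, a gap to compound 2 that lies within the scatter of this assay, while compound 3 gives 3960 nM, a gap that lies beyond it. Compound 4, `COc1cc(-c2nn(-c3cccc(NC(=O)Nc4cccc(C(F)(F)F)c4)c3)cc2-c2ccncc2)ccc1Cl`, differs from compound 2 in one place: (3-(trifluoromethyl)phenyl)amino in place of 3-(trifluoromethyl)phenyl on a carbonyl carbon. Going by the values given here, no measured pair shows this exact change, so the size of the step is open. Compound 1 carries the same kind of linkage as compound 4, and its gap to compound 2 is small, so only a small step towards a lower number, or none beyond the scatter, is expected from compound 2 to compound 4, about a 1.5-fold lower number from compound 2 to compound 4 (0.17 log units; within the scatter). Compound 4 is thus estimated at 1100 nM, with a range from 450 nM to 2700 nM.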

Compound 4, concentration for 50% growth inhibition: 894 nM
Beside the measured number, compound 4's estimate is 1.2-fold (0.09 log units) above it; low and high end bracket the measured number.
By their numbers in this assay, from the lowest: compounds 1, 4 and 2 (each within the scatter of the next); then compound 3.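

In this assay, going by these compounds alone, the first direct reading of (3-(trifluoromethyl)phenyl)amino in place of 3-(trifluoromethyl)phenyl on a carbonyl carbon is a 1.8-fold lower number from compound 2 to compound 4 (0.26 log units; within the scatter) and stays within the scatter, so this change, with its added hydrogen-bond donor, has no resolved effect on the number here. Hydrogen in place of trifluoromethyl on an aromatic carbon likewise gives a 1.1-fold higher number from compound 1 to compound 4 (0.02 log units; within the scatter) and also stays within the scatter. Nothing measured here accounts for either result. The compounds shown leave open whether an amine or a carboxylic acid in place of that trifluoromethyl would move the number beyond the scatter.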